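Hydroxy for ethyl on the side chain: cytotoxicity notes

The source may report more compounds than this note shows. Statements on the series, on what has been measured and on what is new or still open speak of the compounds shown alone.

The series is read in an ADME assay on HepG2 cells (Homo sapiens) for cytotoxicity, read by CellTiter-Glo, with a stated time of 48 h; on this read-out higher numbers stand for lower toxicity in this test and lower numbers for higher toxicity in this test. Compound 1 `CCCCNc1nc2ccc(OC)cc2nc1S(C)(=O)=O` gives 20000 nM. Compound 2 `COc1ccc2nc(NCCO)c(S(C)(=O)=O)nc2c1` carries hydroxy in place of ethyl on a saturated chain carbon, two bonds along the chain from a nitrogen on an aromatic ring and gives 39800 nM, so that a 2.0-fold higher number from compound 1 to compound 2 (0.30 log units; within the scatter). Compound 3 `CCCCNc1nc2cc(OC)ccc2nc1S(C)(=O)=O` holds the same atoms as compound 1 joined differently, and the difference between the two cores is not broken down here. For compound 3 this assay reports only a limit, > 100000 nM, which is the limit of > 100000 nM in this assay, at which 1 of the 3 values shown sits. Compound 4 `COc1ccc2nc(S(C)(=O)=O)c(NCCO)nc2c1` is not yet measured; it differs from compound 3 by hydroxy in place of ethyl on a saturated chain carbon, two bonds along the chain from a nitrogen on an aromatic ring, the same change that takes compound 1 to compound 2. Beside the measured step, in which a 2.0-fold higher number from compound 1 to compound 2 (0.30 log units; within the scatter), the step from compound 3 to compound 4 is expected to be small, estimated as a number no higher from compound 3 to compound 4 (the limit leaves the size open). That expectation rests on one measured pair only, so the spread given is wide. Because compound 3 sits at the limit > 100000 nM, compound 4 is expected to come out as a limit again rather than a number, with an estimated value of 100000 nM and a range from 35000 nM to 250000 nM.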

Compound 4, half-maximal cytotoxic concentration: > 100000 nM
Compound 4: a limit, no number; the forecaster's own chance of this, stated with the estimate: 65%; the middle value sits exactly at the limit.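

Compound 3 and compound 4 both return a limit and not a number, so no step can be read between them: the limit of > 100000 nM in this assay, at which 2 of the 4 values shown sit.

The compounds shown leave open what hydroxy in place of ethyl does to the read-out on the core of compound 3, and how far that read-out lies from the one on the core of compound 1.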